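Methyl to ethyl on the shared core: expected inhibition

The source may report more compounds than this note shows. Statements on the series, on what has been measured and on what is new or still open speak of the compounds shown alone.

Of the compounds shown here, three on one core have been measured. Compound 1 `Cc1nc2c(OCc3ccccc3)cccn2c1Cl` carries chloro on an aromatic carbon; in a functional assay on the whole organism with Rattus norvegicus as the target, with a stated time of 4 h, at a dose of 40 mg/kg by the intraperitoneal route (a higher number here means more inhibition at the dose given (going by the name of the read-out), a lower number less inhibition), compound 1 gives 93%. Compound 2 `COC(=O)Cc1c(C)nc2c(OCc3ccccc3)cccn12` carries (methoxycarbonyl)methyl in place of chloro, and in this assay compound 2 gives 23%. Compound 3 `Cc1nc2c(OCc3ccccc3)cccn2c1C` carries methyl in place of chloro; in this assay compound 3 gives 99%, the highest of the three numbers. The step of a number 6 percentage points higher from compound 1 to compound 3 (within the scatter) lies within the scatter, so compound 1 and compound 3 cannot be ordered against each other. Both large steps involve compound 2: a number 70 percentage points lower from compound 1 to compound 2 (beyond the scatter) and a number 76 percentage points higher from compound 2 to compound 3 (beyond the scatter).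

Compound 4 `CCc1nc2c(OCc3ccccc3)cccn2c1C` differs from compound 3 by methyl in place of hydrogen on a saturated chain carbon bound to an aromatic carbon. Within the data shown here, no measured step alters the methyl of compound 3 in this way. Among the measured compounds shown here, the only step at a saturated chain carbon bound to an aromatic carbon, a number 76 percentage points higher from compound 2 to compound 3 (beyond the scatter), concerns methoxycarbonyl, a different group, so it bears on compound 4 only loosely. The small change from chloro to methyl left the read-out of compound 1 at 93% and that of compound 3 at 99% within the scatter of each other.

The step from methyl to ethyl is therefore expected to stay within the scatter, at a number 7 percentage points lower from compound 3 to compound 4 (within the scatter). Compound 4 is estimated in this assay at 92%, with a range from 72% to 100%.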

Compound 4, a percentage reported as inhibition, in the whole organism at one dose (the size of the read-out at that dose, not a potency): 79%
Beside the measured number, compound 4's estimate is 13 percentage points above it, within the range that was stated.
By their numbers in this assay, from the lowest: compound 2; then compound 4; then compounds 1 and 3 (each within the scatter of the next).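

In this assay, methyl in place of hydrogen on a saturated chain carbon bound to an aromatic carbon gives a number 20 percentage points lower from compound 3 to compound 4 (beyond the scatter) and so registers as a real change. Among these compounds, this is the first reading of a plain methyl to ethyl change at this place: the only earlier step at such a carbon concerned methoxycarbonyl, and the one earlier small change, a number 6 percentage points higher from compound 1 to compound 3 (within the scatter), stayed within the scatter, so the read-out is now seen to respond to a single added carbon here, though by a modest step rather than a large one. Nothing on hand accounts for the lower inhibition with ethyl.

Whether the read-out keeps falling with a longer chain such as propyl or butyl remains open, as methyl and ethyl are the only plain carbon chains shown at this place. Also open, going by these compounds, is how a chain ending in an amine or a carboxylic acid would read here, set against the ethyl of compound 4 and the methyl of compound 3.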